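The source may hold more compounds than are shown below. What is called first, only, known or untested is meant among the compounds shown, and "the series" means these compounds.

Four compounds share one core, a ring system carrying a hydroxypropyl chain on nitrogen and a three-carbon linker to a substituted phenoxy group. Compound 1 `COc1ccc(OCCCOc2cc(=O)n(CCCO)c3c2CC(CC=C(C)C)C(C)(C)C3)cc1` carries a methoxy group on that outer ring. In a functional assay on PANC-1 cells (Homo sapiens) for inhibition, read by MTT assay, with a stated time of 24 h, tested at 10 uM (on this read-out lower numbers stand for less inhibition and higher numbers for more inhibition at the one concentration tested (going by the name of the read-out)), compound 1 gives 47.7%. Compound 2 `CC(C)=CCC1Cc2c(OCCCOc3ccc(Cl)cc3)cc(=O)n(CCCO)c2CC1(C)C` differs from compound 1 only in one place: chloro in place of methoxy on an aromatic carbon. In this assay compound 2 gives 22.7%, so the step of a number 25 percentage points lower from compound 1 to compound 2 (beyond the scatter) is a clear loss of inhibition. Compound 3 `COc1ccc(OCCCOc2cc(=O)n(CCCO)c3c2CC(C/C=C(\C)CCC=C(C)C)C(C)(C)C3)cc1` keeps the methoxy group but changes the side chain on the saturated ring: 3-methylbut-2-en-1-yl in place of hydrogen on a saturated chain carbon bound to a double-bonded chain carbon. In this assay compound 3 gives 20%, and the step of a number 27.7 percentage points lower from compound 1 to compound 3 (beyond the scatter) is again a clear loss. Compound 2 and compound 3 stand close together, within the usual scatter.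

Compound 4 `CC(C)=CCC/C(C)=C/CC1Cc2c(OCCCOc3ccc(Cl)cc3)cc(=O)n(CCCO)c2CC1(C)C` is not yet measured. It differs from compound 3 in one place: chloro in place of methoxy on an aromatic carbon. This is the same change that separates compound 1 from compound 2, made on the core of compound 3 rather than the core of compound 1; the two cores differ as described by 3-methylbut-2-en-1-yl in place of hydrogen on a saturated chain carbon bound to a double-bonded chain carbon, while the place of the exchange is the same in both pairs.

The earlier step, a number 25 percentage points lower from compound 1 to compound 2 (beyond the scatter), was a clear drop. From compound 3 to compound 4 a smaller step is expected, a number 8 percentage points lower from compound 3 to compound 4 (within the scatter), because compound 3 already stands at 20% and a read-out of inhibition cannot fall far below that before reaching zero. For compound 4 the expected value in this assay is 12%, with a range from 0% to 30%.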

Compound 4, a percentage reported as inhibition, at one concentration (the size of the read-out at that concentration, not a potency): 25.2%
The estimate for compound 4 lay 13.2 percentage points below the measured number; the measured number falls inside the stated range.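

In this assay, chloro in place of methoxy gives a number 5.2 percentage points higher from compound 3 to compound 4 (within the scatter), and the added 3-methylbut-2-en-1-yl gives a number 2.5 percentage points higher from compound 2 to compound 4 (within the scatter), so neither change repeats the clear drop it gave when made on compound 1. Set beside that earlier drop, the exchange of methoxy for chloro does not carry from one core to the other: the same change on two cores in this assay, a number 25 percentage points lower (beyond the scatter) from compound 1 to compound 2 and a number 5.2 percentage points higher (within the scatter) from compound 3 to compound 4, 30.2 percentage points apart, beyond the scatter of two such steps The side-chain change does not carry over either, although four compounds tested at a single concentration cannot show why this happens or how other cores would behave: the same change on two cores in this assay, a number 27.7 percentage points lower (beyond the scatter) from compound 1 to compound 3 and a number 2.5 percentage points higher (within the scatter) from compound 2 to compound 4, 30.2 percentage points apart, beyond the scatter of two such steps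

The compounds shown carry only methoxy or chloro on the outer ring, so it remains open whether another group in that place, such as a fluoro group, a nitrile or an amine, would follow the pattern seen with chloro. They also carry only two side chains on the shared core, leaving open how a shorter chain, a saturated chain of similar length or a chain ending in a carboxylic acid would affect the read-out.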